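The source may hold more compounds than are shown below. What is called first, only, known or untested is meant among the compounds shown, and "the series" means these compounds.

Values in a functional assay on MCF7 cells (Homo sapiens) for inhibition, read by sulforhodamine B assay (on this read-out lower numbers stand for stronger inhibition and higher numbers for weaker inhibition), for the measured members of the series:
compound 1 `O=C1C(N2CCCCC2)=CC(=O)c2c1nc1n2[C@H]2OC[C@@H](O)[C@H]2OC1` gives > 8000 nM, which is a limit of the assay.
compound 2 `COc1ccc(NC2=CC(=O)c3nc4n(c3C2=O)[C@H]2OC[C@@H](O)[C@H]2OC4)cc1` gives 5420 nM.
compound 3 `O=C1C=C(Nc2ccccc2)C(=O)c2c1nc1n2[C@H]2OC[C@@H](O)[C@H]2OC1` gives > 4000 nM, which is a limit of the assay.

Compound 1 therefore stands only at a limit, not at a number; of the two limits shown, the limit of > 8000 nM in this assay, at which 1 of the 3 values shown sits, is its own and the limit of > 4000 nM in this assay, at which 1 of the 3 values shown sits, belongs to compound 3. The change to compound 4 `O=C1C(Nc2cccc(Cl)c2)=CC(=O)c2c1nc1n2[C@H]2OC[C@@H](O)[C@H]2OC1` is (3-chlorophenyl)amino in place of piperidin-1-yl on a double-bonded ring carbon. Within the data shown here, the one step measured, a step that the limit leaves unreadable from compound 2 to compound 3, is itself unreadable, and no measured step joins compound 1 to a numbered compound. The values of compound 2 and compound 3 give the only anchor for an arylamino group on this carbon. Compound 4 is estimated at 6000 nM (range 2000 nM to 20000 nM), an expected step of an at least 1.3-fold lower number from compound 1 to compound 4 (0.12 log units; that floor lies within the scatter) that cannot be read against a limit.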

Compound 4, half-maximal inhibitory concentration: 2970 nM
The estimate for compound 4 lay 2.0-fold (0.31 log units) above the measured number; the measured number falls inside the stated range.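

Among these compounds, at this double-bonded ring carbon, (3-chlorophenyl)amino in place of piperidin-1-yl gives the first step in this assay that reads beyond the scatter: an at least 2.6-fold lower number from compound 1 to compound 4 (0.43 log units; beyond the scatter). Compound 1 gives > 8000 nM, a limit of the assay, so the size of this step is only a floor: the limit of > 8000 nM in this assay, at which 1 of the 4 values shown sits.

From the compounds shown here alone, the group on this carbon therefore moves the read-out, although the full size of the change stays unknown. Going by these compounds, what the chlorine itself contributes remains open, as does whether morpholin-4-yl in place of piperidin-1-yl, or methoxy in place of the chlorine, would hold the number of compound 4.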